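The source may report more compounds than this note shows. Statements on the series, on what has been measured and on what is new or still open speak of the compounds shown alone.

Measured so far:
Compound 1 `C[C@@H]1C[C@@H](O)[C@H]2C(C)(C)CCC[C@]2(C)[C@@]1(O)CCC1=CC(=O)OC1` — in a functional assay on A549 cells (Homo sapiens) for cytotoxicity, read by MTT assay, with a stated time of 72 h (on this read-out lower numbers stand for stronger inhibition and higher numbers for weaker inhibition), compound 1 gives < 5 ug/mL, a limit of the assay rather than a number.
Compound 2 `CO[C@H]1C[C@@]2(CC[C@@]3(O2)[C@H](C)CC[C@H]2C(C)(C)[C@@H](OC(C)=O)CC[C@@]23C)[C@H](OC)O1` — in this assay compound 2 gives < 5 ug/mL, likewise a limit.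
Compound 3 `C[C@@H]1C[C@@H](O)[C@H]2C(C)(C)CCC[C@]2(C)[C@@]12CC[C@]1(COC(=O)C1)O2` — in this assay compound 3 gives < 5 ug/mL, again a limit.

Compound 3 thus stands at the limit of < 5 ug/mL in this assay, at which 3 of the 3 values shown sit. For the measured compounds named here, since no measured compound returns a number, no step between measured compounds can be read, and nothing separates compound 3 from the other two. Compound 4 `CC(=O)O[C@@H]1C[C@@H](C)[C@]2(CC[C@]3(COC(=O)C3)O2)[C@@]2(C)CCCC(C)(C)[C@H]12` differs from compound 3 by acetyl in place of hydrogen on an oxygen on a saturated carbon, that is hydroxy to acetoxy. Going by the values given here, with no measured step to lean on, the expected step in this assay is a step that the limit leaves unreadable from compound 3 to compound 4, nothing beyond the usual scatter. Compound 4 is therefore estimated at 3 ug/mL, between 1 ug/mL and 8 ug/mL, and most likely to be reported again as a limit.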

Compound 4, half-maximal inhibitory concentration: < 5 ug/mL
Compound 4: a limit, no number (the forecaster's own chance of this, stated with the estimate: 70%); the middle value is on the limit's open side.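

For the compounds shown here, compound 3 and compound 4 both sit at a limit in this assay, so no step from hydroxy to acetoxy can be read. How potent the compounds shown are, and whether they differ at all, stays open: the limit of < 5 ug/mL in this assay, at which 4 of the 4 values shown sit.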